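Swapping an open-chain amide for a ring in a metabolic stability series

This account rests on a few compounds, and the source may have more. Where it says the series, first, only, none or still open, it means among the compounds named here.

Of the compounds shown here, two of a shared core have so far been tested in an ADME assay on microsomes from liver (Mus musculus) for metabolic stability, with a stated time of 30 min; on this read-out lower numbers stand for a less stable compound and higher numbers for a more stable compound. Compound 1, with the structure `COCC(=O)NC1CCN(c2nc(C)c3cc(NC(=O)/C=C/c4ccc(OC(F)(F)F)cc4)ccc3n2)CC1`, gives 57% in this assay. Compound 2, with the structure `Cc1nc(N2CCC(O)(C3CCC3)CC2)nc2ccc(NC(=O)/C=C/c3ccc(Cl)cc3)cc12`, gives 12% in this assay. Of these two numbers, compound 1 stands highest; compound 2 lies well below it, and that gap is beyond the usual scatter of repeated measurements.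

The next compound follows from compound 1 by a single change. Compound 3 has the structure `Cc1nc(N2CCC(N3CCCC3=O)CC2)nc2ccc(NC(=O)/C=C/c3ccc(OC(F)(F)F)cc3)cc12`. The change is 2-oxopyrrolidin-1-yl in place of ((methoxymethyl)carbonyl)amino on a saturated ring carbon. Both groups have the same count of heavy atoms, but the incoming group closes a ring and loses the hydrogen-bond donor.

Going by the values given here, no measured pair shows this particular change, so the size of its effect is unknown. The expectation is for a step that stays within the scatter, without a clear direction. Compound 3 is expected to give about 55% in this assay, with a likely range from 30% to 80%. This corresponds to an expected step of a number 2 percentage points lower from compound 1 to compound 3 (within the scatter), small next to the scatter.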

Compound 3, percent of the compound remaining: 85%
Beside the measured number, compound 3's estimate is 30 percentage points below it; the whole stated range lies below it.
By their numbers in this assay, from the lowest: compound 2; then compound 1; then compound 3.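

In this assay, replacing ((methoxymethyl)carbonyl)amino with 2-oxopyrrolidin-1-yl on a saturated ring carbon gives a number 28 percentage points higher from compound 1 to compound 3 (beyond the scatter), the first measured sign that the group at this position can shift the read-out while the rest of the molecule stays the same. The two groups have the same count of heavy atoms, so this step does not come with a change in that count; the incoming group instead closes a five-membered ring, has no hydrogen-bond donor and has one hydrogen-bond acceptor fewer. No measurement shown here explains the step.

This single pair changes the ring, the donor and the acceptor count together, so it cannot separate them; the N-methyl version of the open-chain amide, which has no amide hydrogen and no new ring, would help to pull these features apart. The compounds shown also leave open how the ring size matters, as 2-oxopiperidin-1-yl, with its six-membered ring, and a simple amine at the same place are not among them.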